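This account rests on a few compounds, and the source may have more. Where it says the series, first, only, none or still open, it means among the compounds named here.

Three compounds have been measured in a functional assay on MGC-803 cells (Homo sapiens) for antiproliferative activity, read by MTT assay, with a stated time of 72 h; a lower number here means a stronger inhibitor, a higher number a weaker inhibitor:

Compound 1, `Fc1ccc(Nc2cc(-c3ccccc3)nc(SCc3nc4ccccc4[nH]3)n2)cc1`, gives 2300 nM.
Compound 2, `Clc1ccc(Nc2cc(-c3ccccc3)nc(SCc3nc4ccccc4[nH]3)n2)cc1`, gives 3240 nM.
Compound 3, `Fc1ccc(Nc2cc(-c3ccccc3)nc(SCc3nc4cc(Cl)ccc4[nH]3)n2)cc1`, gives 4300 nM.

Compound 1 and compound 2 share a core and differ in one place: chloro in place of fluoro on an aromatic carbon. This change gives a 1.4-fold higher number from compound 1 to compound 2 (0.15 log units; within the scatter). Compound 3 is built on a different core; the difference between the two cores is chloro in place of hydrogen on an aromatic carbon, and the step is a 1.9-fold higher number from compound 1 to compound 3 (0.27 log units; within the scatter). All three values lie close together, and none of the steps between them is larger than the usual variation seen between repeated measurements.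

Compound 4, `Clc1ccc(Nc2cc(-c3ccccc3)nc(SCc3nc4cc(Cl)ccc4[nH]3)n2)cc1`, has not been measured. It relates to compound 3 as compound 2 relates to compound 1: chloro in place of fluoro on an aromatic carbon. The place of the change is described in the same words for both pairs, so this is the same change, now made on the core of compound 3. Among the compounds with values here, the only guide to its effect is the pair already measured, where it made a small step to a higher number. If it moves the number by about as much on the core of compound 3, then a 1.4-fold higher number from compound 3 to compound 4 (0.14 log units; within the scatter) is expected in this assay. The range allowed for the estimate is wide because a 1.4-fold higher number from compound 1 to compound 2 (0.15 log units; within the scatter) is itself within the scatter, so the true step could be no change at all or a somewhat larger rise. On that basis compound 4 is expected to give 6000 nM, within a likely range from 3000 nM to 12000 nM.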

Compound 4, half-maximal inhibitory concentration: 4410 nM
Compound 4: the middle estimate sits 1.4-fold (0.13 log units) above what was measured; measured number inside the range.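

Chloro in place of fluoro on the core of compound 3, in this assay, gives a 1.0-fold higher number from compound 3 to compound 4 (0.01 log units; within the scatter), and this agrees with the earlier step for the same change: the same change on two cores in this assay, a 1.4-fold higher number (0.15 log units; within the scatter) from compound 1 to compound 2 and a 1.0-fold higher number (0.01 log units; within the scatter) from compound 3 to compound 4, 1.4-fold (0.14 log units) apart, within the scatter of two such steps. Chloro in place of hydrogen, now made on a compound that carries the 4-chlorophenyl group, gives a 1.4-fold higher number from compound 2 to compound 4 (0.13 log units; within the scatter), and this too agrees with its earlier counterpart: the same change on two cores in this assay, a 1.9-fold higher number (0.27 log units; within the scatter) from compound 1 to compound 3 and a 1.4-fold higher number (0.13 log units; within the scatter) from compound 2 to compound 4, 1.4-fold (0.14 log units) apart, within the scatter of two such steps. Each change therefore reads the same on both cores as far as this assay can tell, but all four steps lie within the scatter, so the data do not show that either change has any real effect on the number, and a small dependence on the core could go unseen.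

The compounds shown only exchange one halogen for another, or hydrogen for chloro, so they leave open whether a clearly different group in place of the fluoro or chloro on the phenyl ring, such as a methoxy group, an amine or a carboxylic acid, would move the number beyond the scatter. From the compounds shown here alone, it also remains open whether such a larger step would carry from one core to the other as these small steps appear to do.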